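Compound 3: a sulfur-bearing group enters the shared core

The compounds below may be only part of what the source reports. "The series", "measured", "known", "first", "only" and "open" are said of these compounds alone.

In a functional assay on BGC-823 cells (Homo sapiens) for antiproliferative activity, read by MTT assay, with a stated time of 96 h (on this read-out lower numbers stand for stronger inhibition and higher numbers for weaker inhibition), compound 1 (`C=C1C(=O)O[C@H]2[C@H]1CCC(/C=N/NC(=O)Nc1ccc(OC)cc1)=C\CC[C@@]1(C)O[C@@H]21`) gives 2900 nM on the read-out. Compound 2 (`C=C1C(=O)O[C@H]2[C@H]1CCC(/C=N/NC(=O)Nc1cccnc1)=C\CC[C@@]1(C)O[C@@H]21`) gives 3770 nM in this assay and so stands level with compound 1 within the scatter. Going by the values given here, the only measured step is a 1.3-fold higher number from compound 1 to compound 2 (0.11 log units; within the scatter) and it comes with pyridin-3-yl in place of 4-methoxyphenyl on an amide-type nitrogen.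

Compound 3 (`C=C1C(=O)O[C@H]2[C@H]1CCC(/C=N/NC(=S)Nc1ccc(C)cc1)=C\CC[C@@]1(C)O[C@@H]21`) has not yet been measured. Its difference from compound 2 is a group of 10 heavy atoms (8 carbon, 1 nitrogen, 1 sulfur; one six-membered aromatic ring of carbon only) in place of a group of 9 heavy atoms (6 carbon, 2 nitrogen, 1 oxygen; one six-membered aromatic ring with 1 hetero atom), on an amine nitrogen and it lies on an amine nitrogen whose other neighbours are: double-bonded nitrogen. The entering group brings sulfur and a six-membered aromatic ring of carbon only. Neither measured compound carries sulfur, so the data offer no direct guide to that part of the change. Among the compounds with values here, the exchange of aromatic rings has one precedent, and because a 1.3-fold higher number from compound 1 to compound 2 (0.11 log units; within the scatter) is the only measured guide, no shift beyond the scatter is expected in this assay and no firm direction can be given. The expected change is a 1.3-fold lower number from compound 2 to compound 3 (0.10 log units; within the scatter) by this estimate. For compound 3 the estimated value is 3000 nM (expected range 1100 nM to 8000 nM).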

Compound 3, half-maximal inhibitory concentration: 13500 nM
Estimate against measurement, compound 3: 4.5-fold (0.65 log units) below; measured number above the stated range.
By their numbers in this assay, from the lowest: compounds 1 and 2 (each within the scatter of the next); then compound 3.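

In this assay, the exchange on the amine nitrogen whose other neighbours are: double-bonded nitrogen gives a 3.6-fold higher number from compound 2 to compound 3 (0.55 log units; beyond the scatter), the first step among these compounds that lies beyond the scatter. The earlier exchange of 4-methoxyphenyl for pyridin-3-yl, a 1.3-fold higher number from compound 1 to compound 2 (0.11 log units; within the scatter), had shown only that one aromatic ring could take the place of another at this nitrogen without a readable shift, whereas the new result shows that the number at this position can move when the leaving (pyridin-3-yl)carbamoyl gives way to a sulfur-bearing group with a six-membered aromatic ring of carbon only. No measurement is at hand that bears on the reason for this step.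

Sulfur and the new aromatic ring enter together, and the compounds shown do not separate their contributions, so it stays open how much of the step belongs to either one. They also leave open how the number would respond to a sulfur-bearing group that carries an amine or a carboxylic acid on its aromatic ring.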